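Solubility of compound 3 on the chain series

This account rests on a few compounds, and the source may have more. Where it says the series, first, only, none or still open, it means among the compounds named here.

Measured so far in a physicochemical assay for solubility, read by chemiluminescence, measured as kinetic solubility; a higher number here means a more soluble compound, a lower number a less soluble compound 
- compound 1 `COCCn1nc(OC)c2c(NS(=O)(=O)c3cccc(Cl)c3Cl)ncnc21` gives >= 442000 nM (a limit of the assay)
- compound 2 `COc1nn(CCN(C)C)c2ncnc(NS(=O)(=O)c3cccc(Cl)c3Cl)c12` gives 358000 nM (an actual number)

In this assay, within the data shown here, compound 2 gives 358000 nM as the only actual number so far. Compound 1 stands at the limit of >= 442000 nM in this assay, at which 1 of the 2 values shown sits, and that value is a limit, not a number.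

Compound 3 `COc1nn(CC(=O)O)c2ncnc(NS(=O)(=O)c3cccc(Cl)c3Cl)c12` differs from compound 2 by carboxy in place of (dimethylamino)methyl on a saturated chain carbon bound to an aromatic nitrogen and carries carboxy in place of (dimethylamino)methyl on a saturated chain carbon bound to an aromatic nitrogen.

Among the measured compounds shown here, one measured step bears on this change, an at least 1.2-fold lower number from compound 1 to compound 2 (0.09 log units; that floor lies within the scatter) on the same chain. For the measured compounds named here, with that step as the only guide, no change beyond the scatter is expected, and a report as a limit is possible. The expected step is a 1.1-fold higher number from compound 2 to compound 3 (0.03 log units; within the scatter) and it carries no direction. For compound 3 the estimate is 380000 nM with 180000 nM to 500000 nM as the expected range.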

Compound 3, solubility: >= 483000 nM
Compound 3: no number, only a limit; the forecaster's own chance of this, stated with the estimate: 40%; middle value at least 1.2-fold (0.10 log units) away from the limit.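

In this assay compound 3 is reported as a limit, not a number: the limit of >= 483000 nM in this assay, at which 1 of the 3 values shown sits.

Carboxy in place of (dimethylamino)methyl on a saturated chain carbon bound to an aromatic nitrogen gives an at least 1.3-fold higher number from compound 2 to compound 3 (0.13 log units; that floor lies within the scatter), so this place takes a carboxy group, with the hydrogen-bond donor it brings, and no drop in the read-out appears. The step between compound 1 and compound 3 cannot be read, since both values are limits.

From the compounds shown here alone, the real size of the carboxy change stays open while compound 3 sits at a limit. Also open, going by these compounds, is how a plain ethyl chain, a primary amide or a longer chain ending in a carboxylic acid would read at this place in this assay, and whether any of these would give an actual number.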